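Trading 4-bromophenyl for 2,4-dichlorophenyl on compound 3

This account rests on a few compounds, and the source may have more. Where it says the series, first, only, none or still open, it means among the compounds named here.

- compound 1 `COc1cc(/C=C2\CN(C)C/C(=C\c3ccc(Cl)cc3Cl)C2=O)cc(OC)c1` gives 11900 nM
- compound 2 `COc1cc(/C=C2\CN(C)C/C(=C\c3ccc(F)cc3)C2=O)cc(OC)c1OC` gives 10300 nM
- compound 3 `COc1cc(/C=C2\CN(C)C/C(=C\c3ccc(Br)cc3)C2=O)cc(OC)c1OC` gives 12400 nM

All three values come from a functional assay on K562 cells (Homo sapiens) for cytotoxicity, read by MTT assay, with a stated time of 24 h (a lower number here means a stronger inhibitor, a higher number a weaker inhibitor), and lie within the usual scatter of one another, so compound 3 stands level with compound 1 and compound 2. Compound 4 `COc1cc(/C=C2\CN(C)C/C(=C\c3ccc(Cl)cc3Cl)C2=O)cc(OC)c1OC` differs from compound 3 in one place: 2,4-dichlorophenyl in place of 4-bromophenyl on a double-bonded chain carbon bound to a double-bonded ring carbon. The swap sits on a double-bonded chain carbon bound to a double-bonded ring carbon. The closest measured step is a 1.2-fold higher number from compound 2 to compound 3 (0.08 log units; within the scatter), with bromo in place of fluoro on an aromatic carbon. Compound 1 already carries 2,4-dichlorophenyl and gives 11900 nM as well. No step beyond the scatter is therefore expected in this assay. The expected step is a 1.1-fold lower number from compound 3 to compound 4 (0.03 log units; within the scatter). Compound 4 is estimated at 11500 nM, with an expected range from 6000 nM to 22000 nM.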

Compound 4, half-maximal inhibitory concentration: > 20000 nM
Compound 4: a limit, no number; the forecaster's own chance of this, stated with the estimate: 3%; middle value at least 1.7-fold (0.24 log units) from the limit.
By their numbers in this assay, from the lowest: compounds 2, 1 and 3 (each within the scatter of the next). At a limit, above all of these: compound 4.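

In this assay compound 4 alone sits at a limit, not a number: the limit of > 20000 nM in this assay, at which 1 of the 4 values shown sits. The change of group gives an at least 1.6-fold higher number from compound 3 to compound 4 (0.20 log units; that floor lies within the scatter) and an at least 1.9-fold higher number from compound 2 to compound 4 (0.28 log units; that floor lies within the scatter), while methoxy in place of hydrogen on an aromatic carbon gives an at least 1.6-fold higher number from compound 1 to compound 4 (0.22 log units; that floor lies within the scatter), so none of these steps is shown to exceed the scatter. Compound 1 carries the same 2,4-dichlorophenyl and still gives a number, so that group alone does not bring a compound to the limit.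

From the compounds shown here alone, the true value of compound 4 stays open. So does how a phenyl carrying an amine or a carboxylic acid would read at this place.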